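Cyclic phosphorus esters of 5-halo-deoxyuridines, L1210 growth

A few compounds are considered here, and "the series" means these few. Any claim that something is new, unique, unknown or untested is made for them only; others in the source may bear on it.

Measured compounds:
compound 1, `O=c1[nH]c(=O)n([C@H]2C[C@@H]3OP(=O)(OCc4ccccc4)OC[C@H]3O2)cc1I`: > 100 ug/mL
compound 2, `O=c1[nH]c(=O)n([C@H]2C[C@H](O)[C@@H](COP(=O)(O)O)O2)cc1C(F)(F)F`: 0.017 ug/mL
compound 3, `O=c1[nH]c(=O)n([C@H]2C[C@@H]3O[PH](O)(O)OC[C@H]3O2)cc1Br`: 457 ug/mL

In a functional assay on L1210 cells (Mus musculus) for antiproliferative activity (on this read-out lower numbers stand for stronger inhibition and higher numbers for weaker inhibition), compound 3 gives 457 ug/mL, the highest of the two numbers in hand. Compound 2 gives 0.017 ug/mL in this assay, and the gap between compound 3 and compound 2 lies far beyond the scatter. Compound 1 gives > 100 ug/mL, which is a limit of this assay and not a number; (the limit of > 100 ug/mL in this assay, at which 1 of the 3 values shown sits).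

Compound 4, `O=c1[nH]c(=O)n([C@H]2C[C@@H]3O[PH](O)(O)OC[C@H]3O2)cc1I`, is not yet measured. The change from compound 3 is iodo in place of bromo on an aromatic carbon. The cyclic phosphorus ester of compound 3 is kept unchanged. For the measured compounds named here, no measured pair shows the effect of this swap on its own, so compound 4 is expected to sit near compound 3, with a step of a 1.3-fold lower number from compound 3 to compound 4 (0.12 log units; within the scatter) that should stay within the scatter in this assay. Compound 4 is estimated at 350 ug/mL, between 100 ug/mL and 1000 ug/mL, with a fair chance that only a limit is reported.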

Compound 4, concentration for 50% inhibition: >= 500 ug/mL
Compound 4 was reported as a limit; the forecaster's own chance of this, stated with the estimate: 35%; middle value at least 1.4-fold (0.15 log units) from the limit.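

In this assay, for the compounds shown here, the swap of iodo for bromo on this aromatic carbon gives an at least 1.0-fold higher number from compound 3 to compound 4 (0.03 log units; that floor lies within the scatter), the only step so far between compounds that differ in one place. With the cyclic phosphorus ester kept unchanged, this step does not separate iodo from bromo beyond the scatter, but it also does not fix how large the true difference is. The value of compound 4 is a limit and not a number, so only the floor of the step can be read: the limit of >= 500 ug/mL in this assay, at which 1 of the 4 values shown sits.

Going by these compounds, what chloro, an amine or a longer chain would do on this aromatic carbon remains open. Also open is how far the halogen, rather than the phosphorus ester, governs the read-out, as the compounds shown offer no step that isolates the ester.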